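Hydroxy to methoxy on compound 2

The source may report more compounds than this note shows. Statements on the series, on what has been measured and on what is new or still open speak of the compounds shown alone.

In a functional assay on A549 cells (Homo sapiens) for antiproliferative activity, with a stated time of 72 h (on this read-out lower numbers stand for stronger inhibition and higher numbers for weaker inhibition), compound 1 (`COc1cc(OC)c(C(=O)/C=C/c2ccccc2Cl)c(O)c1CN1CCCC1`) gives 2600 nM while compound 2 (`COc1cc(O)c2c(=O)cc(-c3ccccc3Cl)oc2c1CN1CCCCC1`) gives 45500 nM as the higher number of the pair. That gap lies beyond the scatter, but the two structures differ in more than one place, and no single change can be read from it. Compound 3 (`COc1cc(OC)c2c(=O)cc(-c3ccccc3Cl)oc2c1CN1CCCCC1`) departs from compound 2 at one place only. The change is methyl in place of hydrogen on an oxygen on an aromatic ring and consists of methyl in place of hydrogen on an oxygen on an aromatic ring, or hydroxy to methoxy. Going by the values given here, no measured pair shows this change, which leaves the expectation weakly supported. The expected 1.5-fold lower number from compound 2 to compound 3 (0.18 log units; within the scatter) is small and points toward stronger inhibition, with nothing clearly beyond the scatter anticipated. In this assay compound 3 is estimated at 30000 nM with a range from 8000 nM to 90000 nM as the expected span.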

Compound 3, half-maximal inhibitory concentration: > 150000 nM
Compound 3: only a limit was reported; the forecaster's own chance of this, stated with the estimate: 15%; at least 5.0-fold (0.69 log units) between middle value and limit.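

Going by these compounds alone, compound 2 and compound 3 are the first pair that differ in one place only, so this change can now be read on its own. In this assay, methyl in place of hydrogen on an oxygen on an aromatic ring gives an at least 3.2-fold higher number from compound 2 to compound 3 (0.51 log units; beyond the scatter), which moves toward weaker inhibition, so at this position the hydroxy form is the more active of the two. The reading for compound 3 is a limit and not a number, so the step gives a direction and a minimum size only: the limit of > 150000 nM in this assay, at which 1 of the 3 values shown sits.

Still open, going by these compounds, is whether a longer chain such as ethyl on this oxygen, or an amine in place of the hydroxy, would behave as methyl does. Also open, on these data alone, is whether the same change carries over to the core of compound 1.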